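The source may hold more compounds than are shown below. What is called first, only, known or untested is meant among the compounds shown, and "the series" means these compounds.

Measured compounds and values:
compound 1 `CCCc1ccc(NC2=CC(=O)c3c(nc4n3[C@H]3OC[C@@H](O)[C@H]3OC4)C2=O)cc1`: 1920 nM
compound 2 `COc1ccc(NC2=CC(=O)c3c(nc4n3[C@H]3OC[C@@H](O)[C@H]3OC4)C2=O)cc1`: 2150 nM
compound 3 `CCOc1ccc(NC2=CC(=O)c3c(nc4n3[C@H]3OC[C@@H](O)[C@H]3OC4)C2=O)cc1`: 2090 nM

In a functional assay on MGC-803 cells (Homo sapiens) for inhibition, read by sulforhodamine B assay (on this read-out higher numbers stand for weaker inhibition and lower numbers for stronger inhibition), compound 2 gives the highest of the three numbers, though its gaps to compound 3 and to compound 1 both lie within the scatter, so no order among them can be claimed. The three measured steps of a 1.1-fold higher number from compound 1 to compound 2 (0.05 log units; within the scatter), a 1.1-fold higher number from compound 1 to compound 3 (0.04 log units; within the scatter) and a 1.0-fold lower number from compound 2 to compound 3 (0.01 log units; within the scatter) all stay within the scatter and concern only the group on the aromatic ring.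

Compound 4 `O=C1C(N2CCCC2)=CC(=O)c2c1nc1n2[C@H]2OC[C@@H](O)[C@H]2OC1` is not yet measured. Compared with compound 2, the change is pyrrolidin-1-yl in place of (4-methoxyphenyl)amino on a double-bonded ring carbon. Among the compounds with values here, no measured step touches this position or exchanges the arylamine itself, so the measured steps give no direct guide. The exchange is larger than any measured one, and weakening is expected as the more likely outcome, with wide uncertainty. For compound 4 the expected value in this assay is 3000 nM (range 800 nM to 12000 nM), an expected step of a 1.4-fold higher number from compound 2 to compound 4 (0.14 log units; within the scatter).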

Compound 4, half-maximal inhibitory concentration: > 16000 nM
Compound 4 gave a limit, no number; the forecaster's own chance of this, stated with the estimate: 10%; at least 5.3-fold (0.72 log units) between middle value and limit.
By their numbers in this assay, from the lowest: compounds 1, 3 and 2 (each within the scatter of the next). At a limit, above all of these: compound 4.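

In this assay, compound 4 gives > 16000 nM, which is a limit and not a number. Exchanging the whole arylamine on the double-bonded ring carbon gives an at least 7.4-fold higher number from compound 2 to compound 4 (0.87 log units; beyond the scatter), whereas changes to the group on the aromatic ring in compounds 1, 2 and 3 stayed within the scatter. Within the data shown here, this position is therefore sensitive to at least this one exchange, which the earlier compounds could not show.

Still open, going by these compounds, is whether the loss follows the aromatic ring or the amine hydrogen. A cyclohexylamino group or an N-methylanilino group at this position would separate the two.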